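Cytotoxicity notes on an indole carboxamide piperazinone series

The compounds below may be only part of what the source reports. "The series", "measured", "known", "first", "only" and "open" are said of these compounds alone.

Measured so far in an ADME assay on Vero cells (Chlorocebus sabaeus) for cytotoxicity, with a stated time of 7 days; a lower number here means that less compound is tolerated, a higher number that more compound is tolerated:
- compound 1, `COc1ccc2[nH]c(C(=O)N3CC(=O)N(Cc4ccccc4)[C@@H](CN4CCCCC4)C3)cc2c1`: 76900 nM
- compound 2, `COc1ccc2[nH]c(C(=O)N3CC(=O)N(Cc4ccc[nH]4)[C@@H](Cc4ccccc4)C3)cc2c1`: 15200 nM

Compound 1 stands at the higher of the two numbers; compound 2 sits at the lower one, and the gap between the two lies beyond the scatter. Compound 2 differs from compound 1 in more than one place, so nothing is attributed to a single change here.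

Compound 3, `COc1ccc2[nH]c(C(=O)N3CC(=O)N(Cc4ccccc4)[C@@H](COC(C)(C)C)C3)cc2c1`, is not yet measured. It differs from compound 1 by tert-butoxy in place of piperidin-1-yl on a saturated chain carbon bound to a saturated ring carbon. Going by the values given here, no measured pair in the set isolates this change, so the expectation rests on compound 1 alone, whose value in this assay is 76900 nM. The step from compound 1 to compound 3 is expected to be small, a 1.1-fold lower number from compound 1 to compound 3 (0.04 log units; within the scatter), with no direction that can be claimed beyond the scatter. Compound 3 is therefore estimated at 70000 nM, within a range of 25000 nM to 150000 nM.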

Compound 3, half-maximal cytotoxic concentration: 78200 nM
Compound 3: the middle estimate sits 1.1-fold (0.05 log units) below what was measured; the range from low to high includes it.
By their numbers in this assay, from the lowest: compound 2; then compounds 1 and 3 (each within the scatter of the next).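

In this assay, tert-butoxy in place of piperidin-1-yl on a saturated chain carbon bound to a saturated ring carbon gives a step within the scatter (a 1.0-fold higher number from compound 1 to compound 3 (0.01 log units; within the scatter)). Going by these compounds alone, this is the first single-place comparison: at this position, a group with a six-membered non-aromatic ring containing nitrogen and a group with no ring and an oxygen give numbers that cannot be told apart. Nothing at hand accounts for this result.

Still open, on these data alone, is whether the same reading holds for a group of another kind at this position, such as a carboxylic acid or a primary amine on the same chain carbon. Also open, as far as these compounds go, is which of the several differences between compound 1 and compound 2 goes with the lower number of compound 2.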